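The source may report more compounds than this note shows. Statements on the series, on what has been measured and on what is new or still open speak of the compounds shown alone.

a physicochemical assay for solubility, read by nephelometry, measured as kinetic solubility, at pH 6.5, tested at 10 mg/mL (on this read-out higher numbers stand for higher solubility and lower numbers for lower solubility), gives these values
Compound 1 `Cc1c(C(=O)Nc2ccccn2)ccc(F)c1F` gives 25 ug/mL
Compound 2 `Cc1c(F)cccc1C(=O)Nc1ccccn1` gives 25 ug/mL
Compound 3 `Cc1ccccc1C(=O)Nc1cc(C#Cc2ccccc2)ccn1` gives < 1.6 ug/mL as a limit of the assay

Compound 2 stands level with compound 1 on these numbers. Compound 4 `Cc1ccnc(NC(=O)c2cccc(F)c2C)c1` differs from compound 2 by methyl in place of hydrogen on an aromatic carbon with methyl in place of hydrogen on an aromatic carbon, opposite the ring nitrogen. Among the compounds with values here, the one measured step that bears on this is a different swap, hydrogen in place of fluoro on an aromatic carbon, and it shows no change at the digits printed from compound 1 to compound 2 (within the scatter) as its size. Within the data shown here, no measured step adds a methyl, so this is a weak guide. The expected step is a 1.3-fold lower number from compound 2 to compound 4 (0.10 log units; within the scatter) and is not expected to go beyond the scatter in either direction. Compound 4 is estimated at 20 ug/mL in this assay with an expected range from 6 ug/mL to 50 ug/mL for such measurements.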

Compound 4, solubility: 25 ug/mL
For compound 4 the middle estimate is 1.3-fold (0.10 log units) below the measured one; measured number inside the range.
By their numbers in this assay, from the lowest: compounds 1, 2 and 4 (each within the scatter of the next). At a limit, below all of these: compound 3.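

In this assay, methyl in place of hydrogen opposite the ring nitrogen gives no change at the digits printed from compound 2 to compound 4 (within the scatter). Within the data shown here, the only earlier step changed a fluoro, so this is the first measured step at this position, and it shows that a methyl can sit here without a change beyond the scatter. Neither compound 2 nor compound 4 sits at the limit of the read-out, so this step can be read as a real comparison: the limit of < 1.6 ug/mL in this assay, at which 1 of the 4 values shown sits.

The compounds shown leave open whether an amine, a carboxylic acid or a longer chain at this same place would also leave the number level. A single added carbon says little about such groups.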